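Sulfamide series: aryl swap on the shared core

This account rests on a few compounds, and the source may have more. Where it says the series, first, only, none or still open, it means among the compounds named here.

Compound 3 `NS(=O)(=O)NCCC1CCN(c2cc(-c3ccc(Cl)cc3)ncn2)CC1` gives 45200 nM in a functional assay on M21 cells (Homo sapiens) for antiproliferative activity, read by sulforhodamine B assay, with a stated time of 48 h (on this read-out higher numbers stand for weaker inhibition of growth and lower numbers for stronger inhibition of growth), the lowest of the two numbers seen so far. Compound 2 `Cc1ccc(-c2cc(N3CCC(CCNS(N)(=O)=O)CC3)ncn2)cc1` gives 57600 nM, and the step of a 1.3-fold lower number from compound 2 to compound 3 (0.11 log units; within the scatter) stays within the scatter. Compound 1 `NS(=O)(=O)NCC1CCN(c2cc(-c3ccccc3F)ncn2)CC1` gives only a limit of the assay, > 100000 nM, and this value is one of the reasons for caution, since (the limit of > 100000 nM in this assay, at which 1 of the 3 values shown sits). Compound 4 `NS(=O)(=O)NCCC1CCN(c2cc(-c3ccccc3F)ncn2)CC1` differs from compound 3 in one place: 2-fluorophenyl in place of 4-chlorophenyl on an aromatic carbon. Among the compounds with values here, no measured step covers this aryl exchange directly; the one measured step, chloro for methyl, was small. Compound 4 is therefore expected to give 90000 nM (range 35000 nM to 250000 nM) in this assay. The expected step of a 2.0-fold higher number from compound 3 to compound 4 (0.30 log units; within the scatter) leans toward a higher number, with a real chance that only a limit is reported.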

Compound 4, concentration for 50% growth inhibition: 81800 nM
Compound 4: the middle estimate sits 1.1-fold (0.04 log units) above what was measured; the range from low to high includes it.
By their numbers in this assay, from the lowest: compounds 3, 2 and 4 (each within the scatter of the next). At a limit, above all of these: compound 1.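

In this assay, the aryl exchanges at this aromatic carbon stay within the scatter (a 1.8-fold higher number from compound 3 to compound 4 (0.26 log units; within the scatter); a 1.4-fold higher number from compound 2 to compound 4 (0.15 log units; within the scatter)), so 2-fluorophenyl, 4-chlorophenyl and 4-methylphenyl are not told apart here. The (sulfamoylamino)methyl for sulfamoylamino change on the chain yields only a floor, itself within the scatter (an at least 1.2-fold lower number from compound 1 to compound 4 (0.08 log units; that floor lies within the scatter)). Compound 1 stands at a limit of the assay: the limit of > 100000 nM in this assay, at which 1 of the 4 values shown sits.

As far as these compounds go, whether any change at this aromatic carbon moves the number beyond the scatter stays open. Also open, from the compounds shown here alone, is the effect of an amine or a carboxylic acid in place of the sulfamoylamino end, or of a longer chain.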